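The compounds below may be only part of what the source reports. "The series", "measured", "known", "first", "only" and "open" are said of these compounds alone.

Compound 1 `O=c1c2cnn(-c3ccc(F)cc3)c2ncn1CC1(O)CCN(Cc2ccccc2F)CC1`: 9800 nM
Compound 2 `O=c1c2cnn(-c3ccc(F)cc3)c2ncn1CC1(O)CCN(Cc2cccc(Cl)c2)CC1`: "not determined" (no result reported)
Compound 3 `O=c1c2cnn(-c3ccc(F)cc3)c2ncn1CC1(O)CCN(Cc2cc(F)cc(F)c2)CC1`: "not determined" (no result reported)

Three compounds share one core and differ only in the group carried on the saturated chain carbon bound to the amine nitrogen in the ring. In an assay on Sf21 cells for inhibition of ubiquitin carboxyl-terminal hydrolase 7 (Homo sapiens), read by spectrophotometry, with stated times of 30 min and 2 h (a lower number here means a stronger inhibitor, a higher number a weaker inhibitor), compound 1 gives 9800 nM, a weak result. For compound 2 no number exists in this assay, and compound 3 also stands without a number, so compound 2 cannot be placed against compound 1 on the numbers shown.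

Compound 4 `COC(=O)c1ccc(CN2CCC(O)(Cn3cnc4c(cnn4-c4ccc(F)cc4)c3=O)CC2)c(Cl)c1` is built from compound 2 by the change (2-chloro-4-(methoxycarbonyl)phenyl in place of 3-chlorophenyl on a saturated chain carbon bound to an amine nitrogen in a ring). Going by the values given here, no measured step exists that would tell how much this assay responds to such a change, and no number for compound 2 anchors it. Only the weak value of compound 1 gives a bearing. Compound 4 is expected to come out near 3000 nM, with a wide range from 400 nM to 20000 nM.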

Compound 4, half-maximal inhibitory concentration: 800 nM
Estimate against measurement, compound 4: 3.8-fold (0.57 log units) above; the range from low to high includes it.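

In this assay the group on the saturated chain carbon bound to an amine nitrogen in a ring proves able to shift the read-out: 2-chloro-4-(methoxycarbonyl)phenyl in place of 2-fluorophenyl gives a 12-fold lower number from compound 1 to compound 4 (1.09 log units; beyond the scatter) and brings the first clear gain in this series. The step from compound 2 to compound 4 cannot be read, as compound 2 has no number. Nothing shown gives a cause for the gain. The compounds shown leave open whether the chlorine or the methoxycarbonyl group carries the change. They also leave open how a carboxylic acid or a primary amide would fare in place of the methyl ester.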